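Fluoro for nitro on the aryl end of the chain

This account rests on a few compounds, and the source may have more. Where it says the series, first, only, none or still open, it means among the compounds named here.

Of the compounds shown here, three have been measured in a toxicity assay on cells (Macrophage, Mus musculus, strain BALB/c) for cytotoxicity, read by MTT assay; a lower number here means a stronger inhibitor, a higher number a weaker inhibitor. Compound 1 `C=CCOc1cc(OC)c(C(=O)/C=C/c2ccc(F)cc2)c(OCC=C)c1` gives 13800 nM. Compound 2 `COc1cc(O)cc(O)c1C(=O)/C=C/c1ccccc1Br` gives 14600 nM. Compound 3 `C=CCOc1cc(OC)c(C(=O)/C=C/c2ccc([N+](=O)[O-])cc2)c(OCC=C)c1` gives 13200 nM. Compound 3 carries the lowest of the three numbers, but its margins to compound 1 and to compound 2 both lie within the usual scatter, so the three results cannot be told apart. Among the compounds with values here, the one step between single-change neighbours, a 1.0-fold lower number from compound 1 to compound 3 (0.02 log units; within the scatter), likewise stays within the scatter.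

Compound 4 `C=CCOc1cc(OC)c(C(=O)/C=C/c2ccccc2F)c(OCC=C)c1` has not yet been measured. Against compound 3 the change is this: 2-fluorophenyl in place of 4-nitrophenyl on a double-bonded chain carbon bound to a double-bonded chain carbon. Within the data shown here, the only measured step that bears on it is a 1.0-fold lower number from compound 1 to compound 3 (0.02 log units; within the scatter), which exchanged one substituent without moving the number beyond the scatter. Compound 2, with a different core, gives 14600 nM, again close to the others. Nothing here points in either direction. For compound 4 the expected step in this assay is therefore a 1.0-fold higher number from compound 3 to compound 4 (0.01 log units; within the scatter), nothing beyond the scatter. Compound 4 is estimated at 13500 nM, with a range from 7000 nM to 27000 nM.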

Compound 4, half-maximal inhibitory concentration: 13300 nM
For compound 4 the middle estimate is 1.0-fold (0.01 log units) above the measured one; low and high end bracket the measured number.
By their numbers in this assay, from the lowest: compounds 3, 4, 1 and 2 (each within the scatter of the next).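

In this assay the aryl group on a double-bonded chain carbon bound to a double-bonded chain carbon has now been exchanged in two further ways, and neither leaves the scatter. 2-Fluorophenyl in place of 4-nitrophenyl gives a 1.0-fold higher number from compound 3 to compound 4 (0.00 log units; within the scatter) and 2-fluorophenyl in place of 4-fluorophenyl gives a 1.0-fold lower number from compound 1 to compound 4 (0.02 log units; within the scatter) on the same core, so neither swapping the nitro group for fluoro nor altering where the fluoro group sits on the phenyl ring separates these compounds. No supporting evidence bears on why the number stays put.

The compounds shown leave open whether an amine or a carboxylic acid on this phenyl ring would move the number beyond the scatter. They also leave open whether replacing the phenyl ring itself with a longer chain would do so.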